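Replacing the methoxyphenyl on compound 1 with a chlorophenyl

A few compounds are considered here, and "the series" means these few. Any claim that something is new, unique, unknown or untested is made for them only; others in the source may bear on it.

Compound 1, with the structure `COc1cccc(-n2cc(COc3cccc(NC(=O)Nc4ccc(Cl)c(C(F)(F)F)c4)c3)nn2)c1`, is the starting point. In a functional assay on HepG2 cells (Homo sapiens) for inhibition, read by MTT assay, with a stated time of 72 h (on this read-out lower numbers stand for stronger inhibition and higher numbers for weaker inhibition), compound 1 gives 1310 nM, the lowest of the three numbers measured. Compound 2 `CCc1ccc(-n2cc(COc3cccc(NC(=O)Nc4ccc(Cl)c(C(F)(F)F)c4)c3)nn2)cc1` gives 1950 nM, and compound 3 `CC(C)c1cccc(-n2cc(COc3cccc(NC(=O)Nc4ccc(Cl)c(C(F)(F)F)c4)c3)nn2)c1` gives 3250 nM. Neither step from compound 1 is large: there is a 1.5-fold higher number from compound 1 to compound 2 (0.17 log units; within the scatter) and a 2.5-fold higher number from compound 1 to compound 3 (0.39 log units; beyond the scatter), and between the two larger numbers there is a 1.7-fold higher number from compound 2 to compound 3 (0.22 log units; within the scatter).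

Compound 4 `O=C(Nc1cccc(OCc2cn(-c3ccc(Cl)cc3)nn2)c1)Nc1ccc(Cl)c(C(F)(F)F)c1` is the untested one. It differs from compound 1 in one place: 4-chlorophenyl in place of 3-methoxyphenyl on an aromatic nitrogen. Among the compounds with values here, the measured steps that bear on this all change the same phenyl group on the triazole nitrogen, and each change away from the methoxyphenyl gave a higher number, though only the step to compound 3 went beyond the scatter. None of them introduces a chlorine, so the guidance is indirect. A small shift toward a higher number is therefore expected, likely within or just beyond the scatter, as a 1.4-fold higher number from compound 1 to compound 4 (0.14 log units; within the scatter). For compound 4 in this assay the estimate is 1800 nM, with a range from 900 nM to 3800 nM.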

Compound 4, half-maximal inhibitory concentration: 2490 nM
Beside the measured number, compound 4's estimate is 1.4-fold (0.14 log units) below it; low and high end bracket the measured number.
By their numbers in this assay, from the lowest: compounds 1, 2, 4 and 3 (each within the scatter of the next, the first and the last beyond it).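

Chlorine on this phenyl ring is new among these compounds, and in this assay the 4-chlorophenyl group reads much like the groups already tried on this aromatic nitrogen (a 1.9-fold higher number from compound 1 to compound 4 (0.28 log units; within the scatter)), (a 1.3-fold higher number from compound 2 to compound 4 (0.11 log units; within the scatter)) and (a 1.3-fold lower number from compound 3 to compound 4 (0.12 log units; within the scatter)). Compound 4 lies within the scatter of compound 1 and of compound 3, even though those two are separated by a step beyond it, so this position tolerates the change from methoxy to chloro without a clear shift in the number. No measurement of any property of these groups is available to account for these numbers.

Only methoxy, ethyl, isopropyl and chloro appear on this phenyl ring here. From the compounds shown here alone, how an amine or a carboxylic acid on the ring would read in this assay remains open.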